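The compounds below may be only part of what the source reports. "The series", "measured", "known", "first", "only" and "open" are said of these compounds alone.

Working notes on the series, read in an ADME assay (liver) for metabolic stability, with Liver microsome (Rattus norvegicus) as the target, using microsomes and NADPH, with a stated time of 30 min, tested at 1 uM; on this read-out higher numbers stand for fast clearance and lower numbers for slow clearance. Compound 1 `Nc1ccc(S(=O)(=O)N2CCN(c3ncc(C(O)(C(F)(F)F)C(F)(F)F)cc3-c3ccoc3)CC2)cn1` gives 57 mL.min-1.g-1, compound 2 `Nc1ccc(S(=O)(=O)N2CCN(c3ncc(C(O)(C(F)(F)F)C(F)(F)F)cc3-c3cccc(F)c3)CC2)cn1` gives 52 mL.min-1.g-1 and compound 3 `Nc1ccc(S(=O)(=O)N2CCN(c3ncc(C(O)(C(F)(F)F)C(F)(F)F)cc3-c3cncc(F)c3)CC2)cn1` gives 19 mL.min-1.g-1. That last number is the lowest of the three and lies beyond the scatter from both of the others.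

Compound 4 `Nc1ccc(S(=O)(=O)N2CCN(c3ncc(C(O)(C(F)(F)F)C(F)(F)F)cc3-c3ccc4scnc4c3)CC2)cn1` has not yet been measured. Its difference from compound 3 is 1,3-benzothiazol-5-yl in place of 5-fluoropyridin-3-yl on an aromatic carbon, on an aromatic carbon of a six-membered aromatic ring with 1 nitrogen.

All three measured steps change this same group. The first, a 1.1-fold lower number from compound 1 to compound 2 (0.04 log units; within the scatter), stays within the scatter, so furan-3-yl and 3-fluorophenyl do not separate. The other two, a 3.0-fold lower number from compound 1 to compound 3 (0.48 log units; beyond the scatter) and a 2.7-fold lower number from compound 2 to compound 3 (0.44 log units; beyond the scatter), are modest and both come with the arrival of 5-fluoropyridin-3-yl. Compound 4 loses that group, and its six-membered aromatic ring is of carbon only. No group with two rings has been measured here, so the comparison is loose.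

A return towards the numbers of compound 1 and compound 2 is the working expectation. The expected step is a 2.5-fold higher number from compound 3 to compound 4 (0.40 log units; beyond the scatter), a modest rise. The estimate for compound 4 is 48 mL.min-1.g-1, with an expected range from 24 mL.min-1.g-1 to 95 mL.min-1.g-1.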

Compound 4, intrinsic clearance in microsomes: 147 mL.min-1.g-1
Compound 4: middle estimate off by 3.1-fold (0.49 log units), on the low side; measured number above the stated range.
By their numbers in this assay, from the lowest: compound 3; then compounds 2 and 1 (each within the scatter of the next); then compound 4.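

In this assay, 1,3-benzothiazol-5-yl at this position, ortho to a large group, gives the highest number of the series, with steps beyond the scatter against all three other groups: the largest (a 7.7-fold higher number from compound 3 to compound 4 (0.89 log units; beyond the scatter)) against 5-fluoropyridin-3-yl, and smaller ones against 3-fluorophenyl (a 2.8-fold higher number from compound 2 to compound 4 (0.45 log units; beyond the scatter)) and furan-3-yl (a 2.6-fold higher number from compound 1 to compound 4 (0.41 log units; beyond the scatter)). The earlier compounds shown here showed separation in one direction only, downward with 5-fluoropyridin-3-yl, whereas this position now also separates upward from the level shared by furan-3-yl and 3-fluorophenyl, so leaving 5-fluoropyridin-3-yl does not simply restore that level. No measurement shown bears on what lies behind the rise.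

The entering group brings a five-membered aromatic ring with 2 hetero atoms and a six-membered aromatic ring of carbon only in a single change, so the compounds shown do not tell which part goes with the higher number. Also open, from the compounds shown here alone, is how a fused group without sulfur, such as 1,3-benzoxazol-5-yl, or an unfluorinated pyridin-3-yl would read at this position.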